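The source may hold more compounds than are shown below. What is called first, only, known or untested is meant among the compounds shown, and "the series" means these compounds.

In an in vivo ADME assay on the whole organism (strain 129/SvEvBrd x C57BL/6) for pharmacokinetics, with Mus musculus as the target, at a dose of 1 mg/kg by the intravenous route (a higher number here means faster removal of the compound, a lower number slower removal), compound 1 `OC[C@@H](O)[C@@H](O)[C@H](O)c1c[nH]c(-c2cscn2)n1` gives 12.7 mL/min/kg, and compound 2 `OC[C@@H](O)[C@@H](O)[C@H](O)c1c[nH]c(-c2ncccn2)n1` gives 15.2 mL/min/kg. Going by the values given here, with only these two numbers, compound 2 has no separate standing: the one measured step, a 1.2-fold higher number from compound 1 to compound 2 (0.08 log units; within the scatter), stays within the scatter, so the two sit level.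

Compound 3 `OC[C@@H](O)[C@@H](O)[C@H](O)c1c[nH]c(-c2cnccn2)n1` keeps the shared core and changes only the aromatic group on the same aromatic carbon: pyrazin-2-yl in place of pyrimidin-2-yl on an aromatic carbon. Here pyrazin-2-yl takes the place of pyrimidin-2-yl, and the two groups carry the same counts.

The measured step bears on this change, as it too exchanges the aromatic group at that carbon, there pyrimidin-2-yl in place of 1,3-thiazol-4-yl. It is a single step, and no measurement on a pyrazin-2-yl compound exists yet, so it offers limited support and sets no pattern. Taking compound 2 at 15.2 mL/min/kg as the starting point, no step beyond the scatter is expected in this assay. The estimated step is a 1.1-fold lower number from compound 2 to compound 3 (0.04 log units; within the scatter). For compound 3 the expected clearance is 14 mL/min/kg, with an estimated range of 8 mL/min/kg to 25 mL/min/kg.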

Compound 3, clearance: 13.4 mL/min/kg
Beside the measured number, compound 3's estimate is 1.0-fold (0.02 log units) above it; measured number inside the range.
By their numbers in this assay, from the lowest: compounds 1, 3 and 2 (each within the scatter of the next).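

In this assay, pyrazin-2-yl in place of pyrimidin-2-yl swaps two groups with the same counts and only a different arrangement of ring atoms, and the step stays within the scatter (a 1.1-fold lower number from compound 2 to compound 3 (0.05 log units; within the scatter)), so clearance sits level across this pair. The step from the 1,3-thiazol-4-yl compound is also within the scatter (a 1.1-fold higher number from compound 1 to compound 3 (0.02 log units; within the scatter)), so all three aromatic groups on this carbon, the one between two ring nitrogen atoms, now sit level, a reading limited to these three compounds. No measurement in hand accounts for this flatness.

On these data alone, whether an aromatic ring without ring nitrogen, such as phenyl, or a non-aromatic group such as an amine or a carboxylic acid, would give a step beyond the scatter on this carbon remains open. As far as these compounds go, the group of 8 heavy atoms is the same in compound 1, compound 2 and compound 3, so the effect on clearance of a shorter chain there, or of a methoxy in place of one of its hydroxyl groups, also remains open.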